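The compounds below may be only part of what the source reports. "The series", "measured", "known", "first", "only" and "open" are said of these compounds alone.

Working notes on the chain series, read in a functional assay on HEL cells (Homo sapiens); on this read-out higher numbers stand for lower toxicity in this test and lower numbers for higher toxicity in this test. As far as these compounds go, compound 3 `CCCCCc1cc2cn(COCCO)c(O)nc-2n1` gives only a limit, > 200000 nM, so its true position is unknown. Compound 2 `OCCOCn1cc2ccnc-2nc1O`, without the chain, also gives only a limit, > 200000 nM. Compound 1 `CCCCCCCCCCc1cc2cn(COCCO)c(O)nc-2n1`, with the longest chain, gives a number, 32000 nM.

Compound 4 `CCCCCCc1cc2cn(COCCO)c(O)nc-2n1` carries one change: methyl in place of hydrogen on a saturated chain carbon, five bonds along the chain from an aromatic carbon.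

Within the data shown here, two measured steps bear on this change. The readable one is an at least 6.2-fold higher number from compound 1 to compound 3 (0.79 log units; beyond the scatter), and it spans a much larger change in the chain than a single methyl. The other is a step that the two limits leave unreadable from compound 2 to compound 3 and gives no size. Only a small shift towards lower numbers is therefore expected for compound 4, and it may stay hidden behind the limit. The expected step is an at least 1.3-fold lower number from compound 3 to compound 4 (0.12 log units; that floor lies within the scatter). For compound 4 the estimated value is 150000 nM, with an expected range of 70000 nM to 300000 nM.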

Compound 4, half-maximal cytotoxic concentration: > 200000 nM
Compound 4: no number, only a limit (the forecaster's own chance of this, stated with the estimate: 50%); middle value at least 1.3-fold (0.12 log units) from the limit.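

In this assay compound 4 gives only a limit, > 200000 nM, so methyl in place of hydrogen at this chain carbon yields no number. Among these compounds, the steps from compound 2 and from compound 3 to compound 4 cannot be read, while the one readable step is an at least 6.2-fold higher number from compound 1 to compound 4 (0.79 log units; beyond the scatter), which shows that the hexyl chain, like the pentyl chain, stays clearly apart from compound 1. Extending the chain by this one carbon thus leaves the result at the same limit: the limit of > 200000 nM in this assay, at which 3 of the 4 values shown sit.

Still open, as far as these compounds go, is the chain length at which a number first appears on the way from compound 4 to compound 1, a question an octyl chain on the same aromatic carbon would bear on. Also open, from the compounds shown here alone, is how an amine or a carboxylic acid on the chain would read out here.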